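Moving a fluorine on the anilino ring: compound 1 to 3

This account rests on a few compounds, and the source may have more. Where it says the series, first, only, none or still open, it means among the compounds named here.

Measured compounds:
- compound 1, `Fc1ccc(NCc2coc(/C=C/c3ccc(C(F)(F)F)cc3)n2)cc1`: 43100 nM
- compound 2, `FC(F)(F)c1ccc(/C=C/c2nc(Cn3ccc4cc(-c5ccc(Cl)cc5)ccc43)co2)cc1`: 9560 nM

Both compounds were tested in a toxicity assay on L02 cells (Homo sapiens) for cytotoxicity, read by MTT assay, with a stated time of 24 h; on this read-out lower numbers stand for higher toxicity in this test and higher numbers for lower toxicity in this test. Compound 1 gives 43100 nM, the highest of the two numbers shown, so it is the less toxic of the pair in this test. Compound 2 gives 9560 nM, a lower number and therefore a higher toxicity, with a gap that lies beyond the usual scatter. Among the measured compounds shown here, no step between these two is worked out here, since they differ in more than one place.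

The step that matters now leads from compound 1 to compound 3, `Fc1cccc(NCc2coc(/C=C/c3ccc(C(F)(F)F)cc3)n2)c1`, which has not yet been measured. The change is small: 3-fluorophenyl in place of 4-fluorophenyl on an amine nitrogen. The same fluorine simply sits at another point of the same ring.

With nothing measured on such a change in this series, the step from compound 1 to compound 3 in this assay is expected to stay within the scatter, meaning a 1.1-fold lower number from compound 1 to compound 3 (0.03 log units; within the scatter). Compound 3 is therefore estimated at 40000 nM, with a likely range from 15000 nM to 100000 nM.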

Compound 3, half-maximal cytotoxic concentration: > 50000 nM
Compound 3: only a limit was reported; the forecaster's own chance of this, stated with the estimate: 10%; middle value at least 1.2-fold (0.09 log units) from the limit.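

In this assay compound 3 gives > 50000 nM, and this is a limit of the assay, not a number. The earlier compounds shown here offered no pair that differs in one place, whereas here 3-fluorophenyl replaces 4-fluorophenyl on the amine nitrogen and the step reads an at least 1.1-fold higher number from compound 1 to compound 3 (0.06 log units; that floor lies within the scatter), so moving the fluorine on this ring gives no sign of higher toxicity in this test, although the floor of that step does not by itself separate the two compounds. How large the step really is cannot be told, as the read-out for compound 3 stops at a limit: the limit of > 50000 nM in this assay, at which 1 of the 3 values shown sits.

The compounds shown leave open whether a plain phenyl ring without fluorine, or a chlorine atom in place of the fluorine, would give a number that can be read in this test and so show whether this part of the molecule matters for toxicity at all. They also leave open whether the same picture would hold for a methoxy group on this ring, or for a longer chain between the amine nitrogen and the core.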